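A Halogen Swap at the Limit of the Assay

The source may report more compounds than this note shows. Statements on the series, on what has been measured and on what is new or still open speak of the compounds shown alone.

Of the compounds shown here, three sharing one core have been tested in a functional assay on K562 cells (Homo sapiens) for antiproliferative activity, read by MTT assay, with a stated time of 24 h; a lower number here means a stronger inhibitor, a higher number a weaker inhibitor. In that test compound 1 `COc1ccc(C(=O)/C=C/c2cccc([N+](=O)[O-])c2)c2c1C=CC(C)(C)O2` gives 5870 nM. Compound 2 `COc1ccc(C(=O)/C=C/c2cccc(O)c2)c2c1C=CC(C)(C)O2` reaches only a limit, > 10000 nM, and not a number. Compound 3 `COc1ccc(C(=O)/C=C/c2ccc(O)c(Br)c2)c2c1C=CC(C)(C)O2` also stands at a limit, > 10000 nM.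

In compound 4 `COc1ccc(C(=O)/C=C/c2cc(Cl)ccc2O)c2c1C=CC(C)(C)O2`, 5-chloro-2-hydroxyphenyl replaces 3-bromo-4-hydroxyphenyl on a double-bonded chain carbon bound to a double-bonded chain carbon: 5-chloro-2-hydroxyphenyl in place of 3-bromo-4-hydroxyphenyl on a double-bonded chain carbon bound to a double-bonded chain carbon.

Among the measured compounds shown here, no measured step makes this exact swap, but three involve the same position. Hydroxy in place of nitro gives an at least 1.7-fold higher number from compound 1 to compound 2 (0.23 log units; that floor lies within the scatter). Putting 3-bromo-4-hydroxyphenyl in place of 3-nitrophenyl gives an at least 1.7-fold higher number from compound 1 to compound 3 (0.23 log units; that floor lies within the scatter). Exchanging one hydroxy-bearing group for the other gives a step that the two limits leave unreadable from compound 2 to compound 3. These steps offer little guidance, given (the limit of > 10000 nM in this assay, at which 2 of the 3 values shown sit).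

Compound 4 keeps a hydroxy group, so an at least 1.7-fold higher number from compound 1 to compound 3 (0.23 log units; that floor lies within the scatter) is the closest guide, and no step beyond the scatter is expected in this assay, in either direction. The expected change is an at least 1.2-fold lower number from compound 3 to compound 4 (0.09 log units; that floor lies within the scatter). The estimate for compound 4 is 8000 nM, with an expected range of 3000 nM to 16000 nM.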

Compound 4, half-maximal inhibitory concentration: 5510 nM
For compound 4 the middle estimate is 1.5-fold (0.16 log units) above the measured one; low and high end bracket the measured number.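

Compound 4 is the only hydroxy-bearing compound shown with a real number in this assay, and it gives 5510 nM; set against the nitro compound, this is a 1.1-fold lower number from compound 1 to compound 4 (0.03 log units; within the scatter), so at this place on the double-bonded chain carbon a hydroxy-bearing ring with chlorine cannot be told apart from 3-nitrophenyl. Against the other two hydroxy-bearing compounds, the new group gives an at least 1.8-fold lower number from compound 3 to compound 4 (0.25 log units; that floor lies within the scatter) and also an at least 1.8-fold lower number from compound 2 to compound 4 (0.25 log units; that floor lies within the scatter), so a hydroxy group at this position does not by itself go with a value at the limit, although neither floor clears the scatter. The true size of these two steps stays unknown, because compound 2 and compound 3 each stand at a limit and not at a number: the limit of > 10000 nM in this assay, at which 2 of the 4 values shown sit.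

The swap from compound 3 to compound 4 changes the halogen and the place of the hydroxy group together, so the compounds shown leave open which of the two carries the step. They also leave open how this ring would read with an amine or a carboxylic acid on it.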